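Carbamate ester variation and maximal response in the series

The source may hold more compounds than are shown below. What is called first, only, known or untested is meant among the compounds shown, and "the series" means these compounds.

Compound 3 `Cc1nc(S(C)(=O)=O)ccc1Oc1ncnc(OC2CCN(C(=O)O[C@H](C)CF)CC2)c1F` gives 79% in a functional assay on isolated protein for inhibition of Glucose-dependent insulinotropic receptor (Rattus norvegicus), read by HTRF and cAMP accumulation (a higher number here means a larger maximal response, a lower number a smaller maximal response), the lowest of the three measured numbers. Compound 1 `Cc1nc(S(C)(=O)=O)ccc1Oc1ncnc(OC2CCN(C(=O)OC3CCC3)CC2)c1F` gives 81%, and the two lie within the scatter of each other: a number 2 percentage points lower from compound 1 to compound 3 (within the scatter). Compound 2 `Cc1nc(S(C)(=O)=O)ccc1Oc1ncnc(OC2CCN(C(=O)OC(C)(C)C#N)CC2)c1F` gives 97%; a number 18 percentage points lower from compound 2 to compound 3 (beyond the scatter), and a number 16 percentage points higher from compound 1 to compound 2 (beyond the scatter). Compound 4 `Cc1nc(S(C)(=O)=O)ccc1Oc1ncnc(OC2CCN(C(=O)O[C@@H](C)C(F)(F)F)CC2)c1F` differs from compound 3 in one place: 1-(trifluoromethyl)ethyl in place of 1-(fluoromethyl)ethyl on an oxygen next to a carbonyl group. Going by the values given here, no measured step introduces a trifluoromethyl at this position. The two steps among the open-chain esters, one within the scatter and one modest, suggest that this change moves the maximal response only a little, if at all. Compound 4 is therefore expected to give 82%, within 68% to 96%, so that the expected step of a number 3 percentage points higher from compound 3 to compound 4 (within the scatter) stays within the scatter.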

Compound 4, largest response reached (reported as efficacy), in percent of the reference or control that the assay uses: 80%
Compound 4: the middle estimate sits 2 percentage points above what was measured; the measured number falls inside the stated range.
By their numbers in this assay, from the lowest: compounds 3, 4 and 1 (each within the scatter of the next); then compound 2.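

In this assay, 1-(trifluoromethyl)ethyl in place of 1-(fluoromethyl)ethyl on the carbamate oxygen leaves the maximal response within the scatter (a number 1 percentage points higher from compound 3 to compound 4 (within the scatter)). Compound 4 also stays within the scatter of the cyclobutyl ester (a number 1 percentage points lower from compound 1 to compound 4 (within the scatter)), while the 1-cyano-1-methylethyl ester remains apart (a number 17 percentage points lower from compound 2 to compound 4 (beyond the scatter)), so compound 2 alone stands out among the four esters. No available measurement explains this separation.

The compounds shown do not separate the contribution of the nitrile in compound 2 from that of its two methyl groups. Going by these compounds, how a 1,1-dimethylethyl ester, or an ester carrying an amine, would compare remains open.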